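This account rests on a few compounds, and the source may have more. Where it says the series, first, only, none or still open, it means among the compounds named here.

Of the compounds shown here, two of this set have been measured in a functional assay on MDA-MB-231 cells (Homo sapiens) for inhibition, read by MTT assay, with a stated time of 72 h; on this read-out lower numbers stand for stronger inhibition and higher numbers for weaker inhibition. Compound 1, with the structure `Nc1ncnc2c1c(-c1cnc3[nH]ccc3c1)nn2CCCCCCC(=O)NO`, gives 37700 nM. Compound 2, with the structure `Nc1nc2cc(-c3nn(CCC(=O)NO)c4ncnc(N)c34)ccc2o1`, reaches in this assay only > 50000 nM, which is a limit of the assay and not a number. For the measured compounds named here, compound 2 is therefore the one of the two values sitting at the limit of > 50000 nM in this assay, at which 1 of the 2 values shown sits. Compound 3, with the structure `Nc1nc2cc(-c3nn(CCCCCCC(=O)NO)c4ncnc(N)c34)ccc2o1`, differs from compound 2 in one place: 4-(hydroxycarbamoyl)butyl in place of hydroxycarbamoyl on a saturated chain carbon, two bonds along the chain from an aromatic nitrogen. Going by the values given here, no step between two measured compounds covers this change, so any expectation rests on the bare values. Because compound 1 gives 37700 nM and carries the same 6-(hydroxycarbamoyl)hexyl chain, compound 3 is expected to gain, and the step of an at least 1.6-fold lower number from compound 2 to compound 3 (0.22 log units; that floor lies within the scatter) is expected to be modest, toward stronger inhibition. Compound 3 is estimated at 30000 nM, within a range from 8000 nM to 80000 nM.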

Compound 3, half-maximal inhibitory concentration: 8430 nM
Beside the measured number, compound 3's estimate is 3.6-fold (0.55 log units) above it, within the range that was stated.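

In this assay, only the chain on the shared core changes, with 4-(hydroxycarbamoyl)butyl in place of hydroxycarbamoyl on a saturated chain carbon, and this gives an at least 5.9-fold lower number from compound 2 to compound 3 (0.77 log units; beyond the scatter). That step gives only a floor, since compound 2 stands at a limit of the assay and not at a number: the limit of > 50000 nM in this assay, at which 1 of the 3 values shown sits. With the 6-(hydroxycarbamoyl)hexyl chain held constant, the group on the aromatic carbon matters too, as exchanging it gives a 4.5-fold lower number from compound 1 to compound 3 (0.65 log units; beyond the scatter).

Only the two chain lengths on this aromatic group are shown, so it remains open whether the gain builds steadily along the chain, peaks at some intermediate length or continues with a longer chain. On these data alone, it is also open how far the gain depends on the hydroxycarbamoyl end, which a carboxylic acid or an amine at the chain end could test.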